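From phenyl to 4-fluorophenyl: expecting a small step

The source may report more compounds than this note shows. Statements on the series, on what has been measured and on what is new or still open speak of the compounds shown alone.

In a functional assay on HepG2 cells (Homo sapiens) for cytotoxicity, read by MTT assay, with a stated time of 72 h (a lower number here means a stronger inhibitor, a higher number a weaker inhibitor), compound 2 (`CNC(=O)c1cc(Oc2ccc(C(=O)/C=C/c3ccccc3)cc2)ccn1`) gives 6640 nM and stands highest of the two numbers measured, above compound 1 (`CNC(=O)c1cc(Oc2ccc(C(=O)/C=C/c3cccc(Br)c3)cc2)ccn1`) at 2870 nM on the same scale. Compound 3 (`CNC(=O)c1cc(Oc2ccc(C(=O)/C=C/c3ccc(F)cc3)cc2)ccn1`) carries fluoro in place of hydrogen on an aromatic carbon, para to a large group (fluoro in place of hydrogen on an aromatic carbon). Among the measured compounds shown here, only one measured step bears on this change: a 2.3-fold higher number from compound 1 to compound 2 (0.36 log units; beyond the scatter) as hydrogen replaces bromo, a modest step involving a different halogen. Read in reverse, it suggests a lower number with fluoro, so a small downward step is expected, estimated as a 1.4-fold lower number from compound 2 to compound 3 (0.14 log units; within the scatter) and possibly within the scatter. In this assay the estimate for compound 3 is 4800 nM with 2400 nM to 9000 nM as its expected range.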

Compound 3, half-maximal inhibitory concentration: 12600 nM
Compound 3: the middle estimate sits 2.6-fold (0.42 log units) below what was measured; the whole stated range lies below it.
By their numbers in this assay, from the lowest: compound 1; then compounds 2 and 3 (each within the scatter of the next).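

Fluoro on this aromatic carbon, para to a large group, gives a 1.9-fold higher number from compound 2 to compound 3 (0.28 log units; within the scatter), so in this assay this change does not separate the two compounds beyond the scatter. Replacing 3-bromophenyl with 4-fluorophenyl gives a 4.4-fold higher number from compound 1 to compound 3 (0.64 log units; beyond the scatter), which shows that a halogen on this ring does not by itself match the lower number of compound 1. Nothing measured here explains this difference. Whether the halogen or its place matters more stays open, since 3-fluorophenyl and 4-bromophenyl are absent from the compounds shown. Going by these compounds, how an amine or a methoxy group would read on this carbon also remains open.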